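This account rests on a few compounds, and the source may have more. Where it says the series, first, only, none or still open, it means among the compounds named here.

Measured compounds:
compound 1 `O=c1[nH]/c(=N\OCCCc2cccc(F)c2)ccn1[C@@H]1O[C@H](COP(=O)(O)OP(=O)(O)OP(=O)(O)O)[C@@H](O)[C@H]1O` — 100 nM
compound 2 `O=c1[nH]/c(=N\OCCCc2cccc(I)c2)ccn1[C@@H]1O[C@H](COP(=O)(O)OP(=O)(O)OP(=O)(O)O)[C@@H](O)[C@H]1O` — 114 nM
compound 3 `O=c1[nH]/c(=N\OCCCc2cccc([N+](=O)[O-])c2)ccn1[C@@H]1O[C@H](COP(=O)(O)OP(=O)(O)OP(=O)(O)O)[C@@H](O)[C@H]1O` — 95 nM

All three were read in a functional assay on 1321-N1 cells for agonist activity at P2Y purinoceptor 4 (Homo sapiens), read by scintillation counting and inositol phosphate accumulation; on this read-out higher numbers stand for an effect only at larger amounts of compound and lower numbers for an effect already at smaller amounts. They share one core and differ only in the group carried on the aromatic ring at the end of the three-carbon chain. None of these swaps moved the number: a 1.1-fold higher number from compound 1 to compound 2 (0.06 log units; within the scatter), a 1.1-fold lower number from compound 1 to compound 3 (0.02 log units; within the scatter), a 1.2-fold lower number from compound 2 to compound 3 (0.08 log units; within the scatter). Compound 3 therefore stands at a number that cannot be separated from those of compound 1 and compound 2; the three read as one level.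

Compound 4 `O=c1[nH]/c(=N\OCCCc2ccsc2)ccn1[C@@H]1O[C@H](COP(=O)(O)OP(=O)(O)OP(=O)(O)O)[C@@H](O)[C@H]1O` is the next step. It differs from compound 3 by thiophen-3-yl in place of 3-nitrophenyl on a saturated chain carbon, three bonds along the chain from an oxygen. This is a change of a different kind from the measured ones: there the ring stayed and only its substituent was exchanged, here the whole six-membered ring is replaced by a smaller heteroaromatic ring. Among the compounds with values here, the measured steps show that the substituent on the ring is not what sets the number, but no step shows what exchanging the ring itself does. Compound 4 is expected to give about 140 nM, with a range of 50 nM to 400 nM. The expected step is a 1.5-fold higher number from compound 3 to compound 4 (0.17 log units; within the scatter), that is, no change beyond the scatter, with some room for a weaker result.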

Compound 4, half-maximal effective concentration: 20 nM
Compound 4: middle estimate off by 7.0-fold (0.85 log units), on the high side; the measured number lies below the stated range.
By their numbers in this assay, from the lowest: compound 4; then compounds 3, 1 and 2 (each within the scatter of the next).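

In this assay, exchanging the ring itself on the saturated chain carbon, three bonds along the chain from an oxygen, moves the number where exchanging the ring's substituent did not: thiophen-3-yl in place of 3-nitrophenyl gives a 4.8-fold lower number from compound 3 to compound 4 (0.68 log units; beyond the scatter). The same holds for thiophen-3-yl in place of 3-fluorophenyl, with a 5.0-fold lower number from compound 1 to compound 4 (0.70 log units; beyond the scatter), and in place of 3-iodophenyl, with a 5.7-fold lower number from compound 2 to compound 4 (0.76 log units; beyond the scatter), so among these four compounds the ring type separates compound 4 from the single level shared by the other three. Which part of the change goes with the lower number, whether the five-membered ring, the sulfur atom or the absence of any ring substituent, stays unassigned, as nothing shown here bears on it.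

Open, from the compounds shown here alone, is whether an unsubstituted phenyl ring at this position would read with compound 4 or with the level of compounds 1, 2 and 3, a comparison that would separate loss of the substituent from the change of ring. Also open, going by these compounds, is how thiophen-2-yl or furan-3-yl would read in this assay, and whether thiophen-3-yl keeps its number on a longer chain.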